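Removing a methyl from the acyl pyridine: cytotoxicity

This account rests on a few compounds, and the source may have more. Where it says the series, first, only, none or still open, it means among the compounds named here.

Measured so far:
compound 1 `Cc1ccc(-c2nn(-c3ccccc3)cc2-c2nc3ccccc3n2C(=O)c2ccccc2)cc1`: 204000 nM
compound 2 `Cc1ccc(-c2nn(-c3ccccc3)cc2-c2nc3ccccc3n2C(=O)c2ccc(Cl)cc2)cc1`: 216000 nM
compound 3 `Cc1ccc(-c2nn(-c3ccccc3)cc2-c2nc3ccccc3n2C(=O)c2ccc(C)nc2)cc1`: 145000 nM

In an ADME assay on HEK-293T cells (Homo sapiens) for cytotoxicity, read by MTT assay, with a stated time of 24 h (a lower number here means that less compound is tolerated, a higher number that more compound is tolerated), the three compounds sit close together. Compound 3 has the lowest of the three numbers on paper, but that tells little: the step of a 1.4-fold lower number from compound 1 to compound 3 (0.15 log units; within the scatter) and the step of a 1.5-fold lower number from compound 2 to compound 3 (0.17 log units; within the scatter) are both within the scatter, as is a 1.1-fold higher number from compound 1 to compound 2 (0.02 log units; within the scatter). All three compounds share the same core and differ only in the aromatic ring attached to the carbonyl carbon.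

Compound 4 `Cc1ccc(-c2nn(-c3ccccc3)cc2-c2nc3ccccc3n2C(=O)c2cccnc2)cc1` continues this series. It differs from compound 3 by hydrogen in place of methyl on an aromatic carbon.

Going by the values given here, no measured step is the same change. What the data do show is that exchanging one aromatic ring on the carbonyl for another, whether adding a chloro, replacing phenyl by 6-methylpyridin-3-yl, or replacing 4-chlorophenyl by 6-methylpyridin-3-yl, never moved the number beyond the scatter. Dropping a single methyl from that ring is a smaller change still. The expectation is therefore no step beyond the scatter in this assay, with compound 4 tolerated about as well as compound 3, so that the expected step is a 1.1-fold higher number from compound 3 to compound 4 (0.04 log units; within the scatter). For compound 4 the estimated value is 160000 nM, with a range from 80000 nM to 320000 nM.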

Compound 4, half-maximal cytotoxic concentration: 189000 nM
The estimate for compound 4 lay 1.2-fold (0.07 log units) below the measured number, and the stated range covers the measured number.
By their numbers in this assay, from the lowest: compounds 3, 4, 1 and 2 (each within the scatter of the next).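

In this assay, the methyl on the aromatic carbon next to the ring nitrogen can be replaced by hydrogen without a step beyond the scatter (a 1.3-fold higher number from compound 3 to compound 4 (0.12 log units; within the scatter)). Going by these compounds alone, the earlier steps added a chloro or exchanged a whole ring, whereas this one changes only that methyl, so it is the first direct reading of this position. The unsubstituted pyridin-3-yl ring on the carbonyl carbon also stays within the scatter of both phenyl (a 1.1-fold lower number from compound 1 to compound 4 (0.03 log units; within the scatter)) and 4-chlorophenyl (a 1.1-fold lower number from compound 2 to compound 4 (0.06 log units; within the scatter)), so none of the ring changes on the carbonyl shown so far separates these compounds in this cell assay. No supporting measurement is available to explain why the numbers stay so close together.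

The compounds shown leave open whether an amine or a carboxylic acid at this same position would also stay within the scatter, since only methyl and hydrogen have been seen there. They also leave open what a longer chain in place of the methyl would do.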